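Carbonyl substituent swap on the compound 1 core

A few compounds are considered here, and "the series" means these few. Any claim that something is new, unique, unknown or untested is made for them only; others in the source may bear on it.

Measured so far:
compound 1 `CC1=CC[C@H](C(C)C)c2cc(C)c(OC(=O)Nc3ccccc3)cc21`: 75.1%
compound 2 `Cc1cc2c(C(C)C)ccc(C)c2cc1OC(=O)c1ccc(C(F)(F)F)cc1`: 16.8%
compound 3 `COc1cccc(C(=O)Oc2cc3c(C)ccc(C(C)C)c3cc2C)c1`: 31.8%

In a functional assay on MCF7 cells (Homo sapiens) for antiproliferative activity, read by sulforhodamine B assay, with a stated time of 48 h, tested at 50 uM (on this read-out lower numbers stand for less inhibition and higher numbers for more inhibition at the one concentration tested (going by the name of the read-out)), compound 1 gives 75.1%, the highest of the three numbers; compound 3 gives 31.8% and compound 2 gives 16.8%, both beyond the scatter below compound 1. Going by the values given here, compounds 2 and 3 sit on a different core from compound 1, so their values show only that a 4-(trifluoromethyl)phenyl or 3-methoxyphenyl on the carbonyl carbon, attached to that other core, gave weaker inhibition in this assay; no single-change step between measured compounds is available.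

Compound 4 `CC1=CC[C@H](C(C)C)c2cc(C)c(OC(=O)c3ccc(Cl)cc3)cc21` keeps the core of compound 1 and differs by 4-chlorophenyl in place of anilino on a carbonyl carbon. Among the compounds with values here, no measured pair shows this change, so its size is uncertain. Going by the lower numbers of compounds 2 and 3, a downward step from compound 1 to compound 4 of moderate size is expected, a number 30.1 percentage points lower from compound 1 to compound 4 (beyond the scatter). Compound 4 is estimated at 45%, within 20% to 70%.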

Compound 4, a percentage reported as inhibition, at one concentration (the size of the read-out at that concentration, not a potency): 79.7%
Beside the measured number, compound 4's estimate is 34.7 percentage points below it; the whole stated range lies below it.
By their numbers in this assay, from the lowest: compound 2; then compound 3; then compounds 1 and 4 (each within the scatter of the next).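

Going by these compounds alone, the step of a number 4.6 percentage points higher from compound 1 to compound 4 (within the scatter) comes with 4-chlorophenyl in place of anilino on a carbonyl carbon in this assay on the shared core, and it is the first single-change step. On this core, anilino is therefore not required to keep inhibition at this level, and an aromatic ring bonded directly to the carbonyl carbon is compatible with it. Nothing on hand explains why these two groups read alike.

Still open, on these data alone, is whether a longer alkyl chain, a morpholine amide or a benzoic acid on this carbonyl carbon would hold the number on the shared core. Also open, as far as these compounds go, is how 4-(trifluoromethyl)phenyl and 3-methoxyphenyl would read on the core of compound 1, and whether the single-concentration numbers reflect potency.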